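The compounds below may be only part of what the source reports. "The series", "measured", "known", "first", "only" and "open" are said of these compounds alone.

Measured so far in an assay on isolated protein for binding affinity to fibroblast growth factor 2 (Homo sapiens), read by surface plasmon resonance; on this read-out lower numbers stand for tighter binding and higher numbers for weaker binding:
compound 1 `CC(=O)N[C@H]1[C@@H](OC[C@@H](O)[C@@H](O)[C@H](O)[C@@H](O)CNc2cccc(NC(=O)CCCCC3CCSS3)c2)O[C@H](COS(=O)(=O)O)[C@H](O)[C@@H]1O[C@@H]1O[C@H](C(=O)O)[C@@H](O)[C@H](O)[C@H]1OS(=O)(=O)O` gives 23 nM;
compound 2 `CC(=O)N[C@H]1[C@@H](OC[C@@H](O)[C@@H](O)[C@H](O)[C@@H](O)CNc2cccc(NC(=O)CCCCC3CCSS3)c2)O[C@H](COS(=O)(=O)O)[C@H](O)[C@@H]1O[C@@H]1O[C@H](C(=O)O)[C@@H](O)[C@H](OS(=O)(=O)O)[C@H]1O` gives 147 nM;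
compound 3 `CC(=O)N[C@H]1[C@@H](OC[C@@H](O)[C@@H](O)[C@H](O)[C@@H](O)CNc2cccc(NC(=O)CCCCC3CCSS3)c2)O[C@H](CO)[C@H](O)[C@@H]1O[C@@H]1O[C@H](C(=O)O)[C@@H](O)[C@H](OS(=O)(=O)O)[C@H]1OS(=O)(=O)O` gives 95 nM.

Compound 3 holds the second highest of the three numbers in this assay. Its nearest neighbour is compound 2, whose value sits within the usual scatter, so the two cannot be ordered. Compound 1 stands well apart, with a lower number beyond the scatter. Compound 4 `CC(=O)N[C@H]1[C@@H](OC[C@@H](O)[C@@H](O)[C@H](O)[C@@H](O)CNc2cccc(NC(=O)CCCCC3CCSS3)c2)O[C@H](COS(=O)(=O)O)[C@H](O)[C@@H]1O[C@@H]1O[C@H](C(=O)O)[C@@H](O)[C@H](OS(=O)(=O)O)[C@H]1OS(=O)(=O)O` arises from compound 3 by sulfo in place of hydrogen on an oxygen on a saturated carbon, so that compound 4 carries the (sulfooxy)methyl that compound 1 has. Within the data shown here, no pair of measured compounds differs by this change alone. Since compound 1 gives 23 nM with that group present, compound 4 is expected to move toward it, and the expected step of a 3.8-fold lower number from compound 3 to compound 4 (0.58 log units; beyond the scatter) is a drop beyond the scatter. Compound 4 is estimated at 25 nM, between 8 nM and 80 nM.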

Compound 4, dissociation constant: 99 nM
Beside the measured number, compound 4's estimate is 4.0-fold (0.60 log units) below it, and the stated range ends below it.
By their numbers in this assay, from the lowest: compound 1; then compounds 3, 4 and 2 (each within the scatter of the next).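

In this assay, turning hydroxymethyl into (sulfooxy)methyl gives a 1.0-fold higher number from compound 3 to compound 4 (0.02 log units; within the scatter), so at this position the added sulfo brings no change that can be read. Sulfo in place of hydrogen on another oxygen on a saturated carbon is just as silent in one case (a 1.5-fold lower number from compound 2 to compound 4 (0.17 log units; within the scatter)) but not in the other (a 4.3-fold higher number from compound 1 to compound 4 (0.63 log units; beyond the scatter)). The effect of this change therefore depends on the oxygen that carries it, and the (sulfooxy)methyl shared with compound 1 does not by itself go with a low number.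

On these data alone, whether a carboxylic acid or a phosphate at this position would read differently remains open. The data shown offer no explanation for these steps.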